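Swapping the Acyl Group on a Shared Core

The source may hold more compounds than are shown below. What is called first, only, known or untested is meant among the compounds shown, and "the series" means these compounds.

Compound 2 `CN(C)c1ccc(C2CC(c3ccc(-n4cncn4)cc3)=NN2C(=O)c2ccc(C(F)(F)F)cc2)cc1` gives 11.5% in a functional assay on NCI-H1975 cells (Homo sapiens) for inhibition, read by sulforhodamine B assay, tested at 10 uM (on this read-out higher numbers stand for more inhibition at the one concentration tested (going by the name of the read-out) and lower numbers for less inhibition), the higher of the two numbers recorded so far, while compound 1 `CN(C)c1ccc(C2CC(c3ccc(-n4cncn4)cc3)=NN2C(=O)CCCl)cc1` gives -0.7% in this assay . Going by the values given here, the single step joining them, a number 12.2 percentage points higher from compound 1 to compound 2 (beyond the scatter), shows that exchanging the group on the carbonyl carbon moves the read-out only modestly. Compound 3 `CN(C)c1ccc(C2CC(c3ccc(-n4cncn4)cc3)=NN2C(=O)/C=C/c2ccccc2)cc1` differs from compound 2 at the same place: 2-phenylethenyl in place of 4-(trifluoromethyl)phenyl on a carbonyl carbon. Among the compounds with values here, no measured step covers this exchange; the only comparison available, from compound 1 to compound 2, involved a different pair of groups on the same carbonyl carbon and was modest in size. Since one six-membered aromatic ring of carbon only is retained on both sides of the change, the expected step of a number 3.5 percentage points lower from compound 2 to compound 3 (within the scatter) is small and not clearly beyond the scatter in either direction. Compound 3 is estimated at 8%, with a range from -8% to 25%.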

Compound 3, a percentage reported as inhibition, at one concentration (the size of the read-out at that concentration, not a potency): -2.3%
Compound 3: middle estimate off by 10.3 percentage points, on the high side, and the stated range covers the measured number.
By their numbers in this assay, from the lowest: compounds 3 and 1 (each within the scatter of the next); then compound 2.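

The step of a number 13.8 percentage points lower from compound 2 to compound 3 (beyond the scatter) shows that the higher number of compound 2 does not extend to every acyl group with one six-membered aromatic ring of carbon only, as 2-phenylethenyl also carries such a ring. The step of a number 1.6 percentage points lower from compound 1 to compound 3 (within the scatter) places 2-phenylethenyl level with 2-chloroethyl, so among these three groups on the carbonyl carbon, only 4-(trifluoromethyl)phenyl stands apart, and only modestly. Nothing available accounts for this difference between the groups.

As far as these compounds go, it remains open whether the trifluoromethyl group or the directly attached aromatic ring underlies the higher number of compound 2, a question that plain phenyl on the carbonyl carbon would address. From the compounds shown here alone, how a group bearing an amine or a carboxylic acid would read at this position also remains open.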